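Compound 3 to compound 4: chloro in place of fluoro

The source may report more compounds than this note shows. Statements on the series, on what has been measured and on what is new or still open speak of the compounds shown alone.

Measured in an ADME assay on Karpas-1106P cells (Homo sapiens) for cytotoxicity; a lower number here means that less compound is needed, a higher number that more compound is needed for the effect:
- Compound 1 `Cc1ccc(S(=O)(=O)N[C@@H](CC(=O)NC(C)(C)C)C(=O)NCCNC(=O)c2cc(Cl)ccn2)cc1`: > 11100 nM (a limit)
- Compound 2 `Cc1ccc(S(=O)(=O)N[C@@H](CC(=O)NC(C)(C)C)C(=O)NCCNC(=O)c2c(O)cccc2F)cc1`: > 11100 nM (a limit)
- Compound 3 `Cc1ccc(S(=O)(=O)N[C@@H](CC(=O)NC(C)(C)C)C(=O)NCCNC(=O)c2ccccc2F)cc1`: > 11100 nM (a limit)

Compound 3 stands at the limit of > 11100 nM in this assay, at which 3 of the 3 values shown sit. Its entry of > 11100 nM is a limit and not a number, so compound 3 cannot be ranked against compound 1 or compound 2.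

Compound 4 `Cc1ccc(S(=O)(=O)N[C@@H](CC(=O)NC(C)(C)C)C(=O)NCCNC(=O)c2ccccc2Cl)cc1` carries chloro in place of fluoro on an aromatic carbon, ortho to a large group (chloro in place of fluoro on an aromatic carbon). Among the compounds with values here, no measured pair makes this exact exchange. The nearest is a step that the two limits leave unreadable from compound 2 to compound 3, which is also a change on an aromatic carbon. The two changes of the whole aromatic group, a step that the two limits leave unreadable from compound 1 to compound 3 and a step that the two limits leave unreadable from compound 1 to compound 2, bear on it less directly. Within the data shown here, none of the three has a readable size, so the series offers no measured step to scale from.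

With all three compounds at the limit, no step beyond the scatter is expected in this assay, and no direction can be assigned. The expected outcome is a step that the limit leaves unreadable from compound 3 to compound 4. For compound 4 the estimate is 12000 nM, with an expected range of 6000 nM to 25000 nM, and a report as a limit is the likeliest result.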

Compound 4, half-maximal effective concentration: > 11100 nM
Compound 4: only a limit was reported (the forecaster's own chance of this, stated with the estimate: 90%); the middle value is on the limit's open side.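

In this assay compound 4 gives > 11100 nM as a limit and not a number. Within the data shown here, no step from compound 1, compound 2 or compound 3 to compound 4 can be read: the limit of > 11100 nM in this assay, at which 4 of the 4 values shown sit.

The compounds shown leave open whether any exchange on the aromatic group changes the result in this assay, as none has a numerical value.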